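This account rests on a few compounds, and the source may have more. Where it says the series, first, only, none or still open, it means among the compounds named here.

In a functional assay on BCG823 cells (Homo sapiens) for inhibition, read by MTT assay, with a stated time of 72 h (on this read-out lower numbers stand for stronger inhibition and higher numbers for weaker inhibition), compound 3 `CN(C(=O)NC(=O)c1ccccc1F)c1nc(C(F)(F)F)c(C(=O)N/N=C/c2ccccc2C(F)(F)F)s1` gives 4.67 ug/mL. Compound 1 `CN(C(=O)NC(=O)c1ccc(F)c(F)c1)c1nc(C(F)(F)F)c(C(=O)N/N=C/c2ccccc2C(F)(F)F)s1` gives 3.66 ug/mL, and the two sit within the scatter of each other. Compound 2 `CN(C(=O)NC(=O)c1ccc(C(F)(F)F)cc1)c1nc(C(F)(F)F)c(C(=O)N/N=C/c2ccc(C(F)(F)F)cc2)s1` gives only a limit, > 100 ug/mL, at the limit of > 100 ug/mL in this assay, at which 1 of the 3 values shown sits. Compound 4 `CN(C(=O)NC(=O)c1ccc(C(F)(F)F)cc1)c1nc(C(F)(F)F)c(C(=O)N/N=C/c2ccccc2C(F)(F)F)s1` differs from compound 3 by 4-(trifluoromethyl)phenyl in place of 2-fluorophenyl on a carbonyl carbon. For the measured compounds named here, the only measured step on the carbonyl aryl is a 1.3-fold higher number from compound 1 to compound 3 (0.11 log units; within the scatter), an exchange of one fluorinated phenyl for another; no measured step replaces a fluorophenyl with a trifluoromethylphenyl at this position. Compound 2 carries the same 4-(trifluoromethyl)phenyl on the carbonyl carbon and gave only a limit. Compound 4 is therefore expected to weaken, estimated at 15 ug/mL with a range of 4 ug/mL to 100 ug/mL, a step of a 3.2-fold higher number from compound 3 to compound 4 (0.51 log units; beyond the scatter), with a fair chance that only a limit is reported.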

Compound 4, half-maximal inhibitory concentration: 2.53 ug/mL
Compound 4: middle estimate off by 5.9-fold (0.77 log units), on the high side; the measured number lies below the stated range.
By their numbers in this assay, from the lowest: compounds 4, 1 and 3 (each within the scatter of the next). At a limit, above all of these: compound 2.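

On the carbonyl carbon, 4-(trifluoromethyl)phenyl in this assay gives a 1.8-fold lower number from compound 3 to compound 4 (0.27 log units; within the scatter) and a 1.4-fold lower number from compound 1 to compound 4 (0.16 log units; within the scatter), so this group keeps the number in line with both fluorinated phenyls. The weak result of compound 2 therefore does not follow this group on the carbonyl carbon, and the large difference lies on the carbon with a double bond to nitrogen, with an at least 39-fold lower number from compound 2 to compound 4 (1.59 log units; beyond the scatter) for 2-(trifluoromethyl)phenyl in place of 4-(trifluoromethyl)phenyl. Compound 2 gives a limit, not a number: the limit of > 100 ug/mL in this assay, at which 1 of the 4 values shown sits.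

Still open, on these data alone, is how an amine or a carboxylic acid on the phenyl at the carbonyl carbon would read. Also open, as far as these compounds go, is whether a methoxy group in place of trifluoromethyl on the phenyl at the carbon with a double bond to nitrogen would keep the number of compound 4 2.53 ug/mL.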